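Title: From Fluoro to Methoxy on the Pendant Phenyl Ring

The compounds below may be only part of what the source reports. "The series", "measured", "known", "first", "only" and "open" are said of these compounds alone.

Measured compounds:
compound 1 `Cc1ccc(-c2ccc(C)n2-c2ccc(-c3nc4ccc(F)cc4s3)cc2)cc1`, 16700 nM
compound 2 `Cc1ccc(-c2ccc(F)cc2)n1-c1ccc(-c2nc3ccc(F)cc3s2)cc1`, 14100 nM

Among the measured compounds shown here, compound 2 stands at the lower of the two numbers so far in a functional assay on MDA-MB-231 cells (Homo sapiens) for cytotoxicity, read by MTT assay, with a stated time of 72 h (on this read-out higher numbers stand for weaker inhibition and lower numbers for stronger inhibition), but its neighbour compound 1 gives 16700 nM, and the step of a 1.2-fold lower number from compound 1 to compound 2 (0.07 log units; within the scatter) is within the scatter, so the two cannot be told apart. Compound 3 `COc1ccc(-c2ccc(C)n2-c2ccc(-c3nc4ccc(F)cc4s3)cc2)cc1` has not been measured. It differs from compound 2 as follows: methoxy in place of fluoro on an aromatic carbon. For the measured compounds named here, the only step on record that bears on this position is a 1.2-fold lower number from compound 1 to compound 2 (0.07 log units; within the scatter), which shows that exchanging one small group for another on that aromatic carbon left the number where it was. Going by the values given here, with no step for methoxy itself, the expectation for compound 3 is a step of a 1.0-fold lower number from compound 2 to compound 3 (0.00 log units; within the scatter), that is, nothing beyond the scatter. Compound 3 is therefore estimated at 14000 nM, with a range from 6000 nM to 35000 nM.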

Compound 3, half-maximal inhibitory concentration: 19000 nM
The estimate for compound 3 lay 1.4-fold (0.13 log units) below the measured number; low and high end bracket the measured number.
By their numbers in this assay, from the lowest: compounds 2, 1 and 3 (each within the scatter of the next).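

In this assay the exchange of fluoro for methoxy gives a 1.3-fold higher number from compound 2 to compound 3 (0.13 log units; within the scatter) and the exchange of methyl for methoxy gives a 1.1-fold higher number from compound 1 to compound 3 (0.06 log units; within the scatter), so a third group on this aromatic carbon leaves compound 3 indistinguishable from both neighbours. The earlier pair covered only methyl and fluoro, whereas 4-methoxyphenyl brings two heavy atoms and a hydrogen-bond acceptor in place of the single fluorine, and the number still does not move beyond the scatter. No independent measurement is available to explain this result.

From the compounds shown here alone, whether an amine, a carboxylic acid or a longer chain such as butoxy on this carbon would shift the number beyond the scatter remains open. Also open is whether any group at this position can do so, since the three compounds shown span only methyl, fluoro and methoxy.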